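Trimming One Acetyl Group: Diacetylamino to Acetamido

The compounds below may be only part of what the source reports. "The series", "measured", "known", "first", "only" and "open" are said of these compounds alone.

Compound 1 `Cc1ncc(-c2ccccc2)c(C(C)(C)C)n1` and compound 2 `CC(=O)N(C(C)=O)c1ncc(-c2ccccc2)c(C(C)(C)C)n1` share one core and were tested in a functional assay on the whole organism for inhibition, with Rattus norvegicus as the target, with stated times of 1 h and 3.5 h, at a dose of 100 mg/kg by the oral route; on this read-out lower numbers stand for less inhibition and higher numbers for more inhibition at the one dose given (going by the name of the read-out). In this assay compound 1 gives 22%, and compound 2 gives 22%. The single measured step, no change at the digits printed from compound 1 to compound 2 (within the scatter), leaves compound 2 level with compound 1 at the digits shown, so nothing so far separates the two.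

Compound 3 `CC(=O)Nc1ncc(-c2ccccc2)c(C(C)(C)C)n1` has not yet been measured. It differs from compound 2 as follows: hydrogen in place of acetyl on an amide-type nitrogen. The same difference, cut one bond further out, reads diacetylamino to acetamido. For the measured compounds named here, only the step from compound 1 to compound 2 bears on this change, and it was no change within the scatter, so no step beyond the scatter is expected here either. The estimated step is no change at the digits printed from compound 2 to compound 3 (within the scatter). Compound 3 is therefore expected to give 22%, with a likely range from 8% to 38%.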

Compound 3, a percentage reported as inhibition, in the whole organism at one dose (the size of the read-out at that dose, not a potency): 29%
For compound 3 the middle estimate is 7 percentage points below the measured one, and the stated range covers the measured number.
By their numbers in this assay, from the lowest: compounds 1, 2 and 3 (each within the scatter of the next).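

In this assay, hydrogen in place of acetyl on the amide-type nitrogen gives a number 7 percentage points higher from compound 2 to compound 3 (within the scatter), so this read-out at its one dose does not tell the diacetylamino and acetamido groups apart. Acetamido in place of methyl on the aromatic carbon gives a number 7 percentage points higher from compound 1 to compound 3 (within the scatter), so methyl, diacetylamino and acetamido at this position all lie within the scatter of one another. No other measurement bears on this result.

As far as these compounds go, whether an amine with neither acetyl group on the nitrogen, or a carboxylic acid on the same aromatic carbon, would give a number beyond the scatter remains open. Also open, from the compounds shown here alone, is how these three compounds would compare at other doses, as a single dose shows the size of the read-out and not a potency.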